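The compounds below may be only part of what the source reports. "The series", "measured", "known", "first", "only" and "open" are said of these compounds alone.

Of the compounds shown here, two have been measured in an assay on membranes from brain for displacement of a labelled ligand from Neuronal acetylcholine receptor; alpha4/beta2 (Rattus norvegicus); on this read-out lower numbers stand for stronger inhibition and higher numbers for weaker inhibition. Compound 1, `c1cnc2[nH]c(C[C@@H]3CCCN3)cc2c1`, gives 2750 nM in this assay. Compound 2, `Clc1ccc2cc(C[C@H]3CCCN3)[nH]c2n1`, gives 147 nM in this assay, the lower of the two numbers, with compound 1 standing at a higher number beyond the usual scatter. Compound 3, `Clc1ccc2cc(C[C@@H]3CCCN3)[nH]c2n1`, is still to be measured. (the two compounds have the same atoms and bonds and differ only in configuration as drawn: 1 of 1 stereo elements differ; a stereocentre at a saturated ring carbon is drawn R in compound 2 and S in compound 3). Among the measured compounds shown here, no step of this kind has been measured here, so the size of the step from compound 2 to compound 3 is open; a move to a higher number is expected, around a 10-fold higher number from compound 2 to compound 3 (1.01 log units; beyond the scatter). For compound 3 the expected value is 1500 nM, with a range from 300 nM to 8000 nM.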

Compound 3, inhibition constant: 3720 nM
Beside the measured number, compound 3's estimate is 2.5-fold (0.39 log units) below it; measured number inside the range.
By their numbers in this assay, from the lowest: compound 2; then compounds 1 and 3 (each within the scatter of the next).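

In this assay, swapping the configuration at one saturated ring carbon from R to S is a large move, a 25-fold higher number from compound 2 to compound 3 (1.40 log units; beyond the scatter), so the spatial arrangement at this carbon matters for this read-out, even with nothing else changed: the fact that compounds 2 and 3 differ only in the configuration as drawn With the S configuration, chloro in place of hydrogen gives no clear change, a 1.4-fold higher number from compound 1 to compound 3 (0.13 log units; within the scatter). Still open, from the compounds shown here alone, is what hydrogen in place of chloro would give with the R configuration, and how a bromo or a methoxy group would read in the chloro's place.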